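This account rests on a few compounds, and the source may have more. Where it says the series, first, only, none or still open, it means among the compounds named here.

Three chalcones carrying the same core were compared in a functional assay on HaCaT cells (Homo sapiens), read by fluorescence and BrdU incorporation, with a stated time of 48 h, tested at 10 uM; a lower number here means a stronger effect, a higher number a weaker effect of the compound at the concentration tested. Compound 1 `COc1cc(O)c(C(=O)/C=C/c2ccc(F)cc2)c(OC)c1` was reported as "not active" (no number reported) in this assay. Compound 2 `COc1cc(OC)c(C(=O)/C=C/c2ccc(Cl)cc2)c(OC)c1` gave 26% in this assay. Compound 3 `COc1cc(O)c(C(=O)/C=C/c2ccccc2SC)c(OC)c1` gave 51% in this assay. Among the entries with a number, compound 2 stands lowest, which on this read-out means the strongest effect at the concentration tested; its nearest neighbour, compound 3, lies beyond the scatter above it, and compound 1 contributes no number at all.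

The step now followed leads from compound 2 to compound 4 `COc1cc(OC)c(C(=O)/C=C/c2ccccc2)c(OC)c1`, which has not yet been measured in this assay. The difference between the two structures is hydrogen in place of chloro on an aromatic carbon. Going by the values given here, no step between measured compounds of this set is available to calibrate what such a change does here, so the expectation must rest on the standing of compound 2 alone.

With the chloro group gone, a somewhat weaker effect, that is a higher number, is expected for compound 4, amounting to a step of a number 16 percentage points higher from compound 2 to compound 4 (beyond the scatter) that may or may not exceed the scatter. Compound 4 is estimated to give 42% in this assay, within a range from 22% to 68%.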

Compound 4, a percentage reported as activity, at one concentration (the size of the read-out at that concentration, not a potency): 18%
Compound 4: middle estimate off by 24 percentage points, on the high side; the whole stated range lies above it.
By their numbers in this assay, from the lowest: compounds 4 and 2 (each within the scatter of the next); then compound 3.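

Going by these compounds alone, the exchange of 4-chlorophenyl for phenyl gives a number 8 percentage points lower from compound 2 to compound 4 (within the scatter) in this assay and provides the first step in this set that can be read directly. At this place, para to a large group, the chloro group is therefore not required for the effect seen at the concentration tested, since compound 4 with hydrogen there remains within the scatter of compound 2. The data shown offer no measurement that could explain this result, so the step stands as an observation only.

As far as these compounds go, it remains open whether this place accepts other groups equally well or whether the result holds only for hydrogen and chloro, and a methoxy group, an amine or a carboxylic acid on the same aromatic carbon would test that on the shared core. Also open is what an exchange between hydroxy and methoxy on the core does, as no pair of compounds shown differs in that one place alone.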